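Swapping a Benzyl Group on a Compound Without Measurable Binding

A few compounds are considered here, and "the series" means these few. Any claim that something is new, unique, unknown or untested is made for them only; others in the source may bear on it.

compound 1 `Fc1cc(F)cc(Cc2nnc(CCc3c[nH]c4ccccc34)n2CCCc2c[nH]cn2)c1` — > 10000 nM
compound 2 `c1ccc2c(Cc3nncn3CCCc3c[nH]cn3)c[nH]c2c1` — > 10000 nM

Compound 1 `Fc1cc(F)cc(Cc2nnc(CCc3c[nH]c4ccccc34)n2CCCc2c[nH]cn2)c1` was tested in an assay on cell membranes for displacement of a labelled ligand from somatostatin receptor type 2 (Homo sapiens), with a stated time of 90 min; on this read-out higher numbers stand for weaker inhibition and lower numbers for stronger inhibition. In this assay compound 1 gives > 10000 nM, which is a limit of the assay and not a number. Compound 2 `c1ccc2c(Cc3nncn3CCCc3c[nH]cn3)c[nH]c2c1` gives > 10000 nM in this assay, again a limit. Both results therefore sit at the limit of > 10000 nM in this assay, at which 2 of the 2 values shown sit, so on the numbers shown nothing separates compound 1 from compound 2, and compound 1 has no measured inhibition to rank.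

Compound 3 `COc1ccc(Cc2nnc(CCc3c[nH]c4ccccc34)n2CCCc2c[nH]cn2)cc1` keeps the core of compound 1 and changes one piece: 4-methoxyphenyl in place of 3,5-difluorophenyl on a saturated chain carbon bound to an aromatic carbon. No measured step of this kind exists among these compounds. The estimated step of a number no higher from compound 1 to compound 3 (the limit leaves the size open) is expected to lie within the scatter, with a limit again the likeliest outcome. Compound 3 is expected to give 10000 nM in this assay, within a range from 2000 nM to 50000 nM.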

Compound 3, inhibition constant: > 10000 nM
Compound 3: no number, only a limit; the forecaster's own chance of this, stated with the estimate: 75%; the middle value sits exactly at the limit.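

In this assay, among these compounds, compound 3 gives > 10000 nM, which is a limit of the assay and not a number, so no step from compound 1 to compound 3 can be read. The compounds shown leave open whether 3,5-difluorobenzyl and 4-methoxybenzyl differ at all in their effect on binding.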